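A few compounds are considered here, and "the series" means these few. Any claim that something is new, unique, unknown or untested is made for them only; others in the source may bear on it.

Going by the values given here, in a functional assay on NUGC-3 cells (Homo sapiens) for antiproliferative activity, read by XTT assay (on this read-out higher numbers stand for weaker inhibition and lower numbers for stronger inhibition), compound 1 `O=c1c(Cc2coc3cccc(OCC4CCCCC4)c3c2=O)coc2ccccc12` gives 3530 nM, the only actual number available so far. Compound 2 `CC(C)COc1cccc2occ(Cc3coc4ccccc4c3=O)c(=O)c12` carries isopropyl in place of the cyclohexyl of compound 1 on the saturated chain carbon bound to the oxygen. Compound 2 gives > 10000 nM, which is a limit of the assay and not a number. Among the compounds with values here, the only measured change, an at least 2.8-fold higher number from compound 1 to compound 2 (0.45 log units; beyond the scatter), lies beyond the scatter, so compound 1 stands as the more active of the two.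

Compound 3 `COc1ccc2c(=O)c(Cc3coc4cccc(OCC5CCCCC5)c4c3=O)coc2c1` keeps the cyclohexyl of compound 1 and has methoxy in place of hydrogen on an aromatic carbon. Within the data shown here, the measured step of an at least 2.8-fold higher number from compound 1 to compound 2 (0.45 log units; beyond the scatter) concerns the group on the chain, not this aromatic carbon, and no measured step covers a methoxy group. No shift beyond the scatter is therefore expected in this assay, although either direction remains possible. The expected change is a 1.0-fold lower number from compound 1 to compound 3 (0.00 log units; within the scatter). For compound 3 the estimated value is 3500 nM, with an expected range from 1200 nM to 10000 nM.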

Compound 3, half-maximal inhibitory concentration: 1440 nM
The estimate for compound 3 lay 2.4-fold (0.39 log units) above the measured number; the measured number falls inside the stated range.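

On an aromatic carbon of the six-membered ring of carbon only, methoxy in place of hydrogen gives a 2.5-fold lower number from compound 1 to compound 3 (0.39 log units; beyond the scatter) in this assay. Going by these compounds alone, the earlier step changed only the group on the chain, so this is the first sign that the number also responds to a change on this aromatic ring, here toward stronger inhibition with the cyclohexyl kept in place. The compounds shown offer no measured property that would explain this shift.

Methoxy is the only group shown on this carbon, so it remains open whether a hydroxyl group, a chlorine atom or a longer chain such as ethoxy would lower the number as well, and whether methoxy would do the same on the other carbons of this ring. On these data alone, it is also open whether methoxy would bring a measurable number to the isopropyl-bearing compound 2, whose > 10000 nM is a limit of the assay and not a number.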